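Amide nitrogen substituent in the chlorophenyl isovaleramide series

The source may report more compounds than this note shows. Statements on the series, on what has been measured and on what is new or still open speak of the compounds shown alone.

The shared core is that of compound 1 `CNC(=O)[C@H](c1ccc(Cl)cc1)C(C)C`, and the read-out throughout is a functional assay on CHO cells for agonist activity at Free fatty acid receptor 2 (Homo sapiens), read by cAMP accumulation; a lower number here means a stronger inhibitor, a higher number a weaker inhibitor. In this assay compound 1 gives 11000 nM, the lowest of the two numbers available. Compound 3 `CC(C)[C@H](C(=O)Nc1ncc[nH]1)c1ccc(Cl)cc1` gives 20000 nM in this assay, and the step of a 1.8-fold higher number from compound 1 to compound 3 (0.26 log units; within the scatter) is within the scatter. Compound 2 `CC(C)[C@H](C(=O)NCc1ccccc1)c1ccc(Cl)cc1` reaches only the limit of this assay, > 100000 nM, which is a limit and not a number; it is one of the values covered by the limit of > 100000 nM in this assay, at which 1 of the 3 values shown sits. The step of an at least 9.0-fold higher number from compound 1 to compound 2 (0.95 log units; beyond the scatter) is beyond the scatter, as is an at least 5.0-fold lower number from compound 2 to compound 3 (0.69 log units; beyond the scatter).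

Compound 4 `CC(C)[C@H](C(=O)Nc1cnns1)c1ccc(Cl)cc1` has not been measured in this assay. It differs from compound 1 by 1,2,3-thiadiazol-5-yl in place of methyl on an amide-type nitrogen. The step that bears on it most closely is a 1.8-fold higher number from compound 1 to compound 3 (0.26 log units; within the scatter), a five-membered aromatic ring in place of methyl on the same nitrogen, which stayed within the scatter; an at least 5.0-fold lower number from compound 2 to compound 3 (0.69 log units; beyond the scatter) shows that such a ring is tolerated where benzyl is not. A step of comparable size is therefore expected, a 1.4-fold higher number from compound 1 to compound 4 (0.13 log units; within the scatter), with no change beyond the scatter the most likely outcome. Compound 4 is estimated at 15000 nM in this assay, within the range 6000 nM to 50000 nM.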

Compound 4, half-maximal inhibitory concentration: 57000 nM
Estimate against measurement, compound 4: 3.8-fold (0.58 log units) below, outside the stated range (above it).
By their numbers in this assay, from the lowest: compounds 1 and 3 (each within the scatter of the next); then compound 4. At a limit, above all of these: compound 2.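

On the amide-type nitrogen, a five-membered aromatic ring in place of methyl is not always tolerated in this assay: the thiadiazole gives a 5.2-fold higher number from compound 1 to compound 4 (0.71 log units; beyond the scatter), whereas the imidazole of compound 3 stayed within the scatter of methyl. The identity of the ring therefore matters and not just its presence, as replacing 1H-imidazol-2-yl with 1,2,3-thiadiazol-5-yl gives a 2.9-fold higher number from compound 3 to compound 4 (0.45 log units; beyond the scatter). The value of compound 2 is a limit and not a number, and an at least 1.7-fold lower number from compound 2 to compound 4 (0.24 log units; that floor lies within the scatter) has a floor within the scatter, so this step does not firmly separate the thiadiazole from benzyl: the limit of > 100000 nM in this assay, at which 1 of the 4 values shown sits.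

The compounds shown leave open whether the step from the imidazole to the thiadiazole follows the sulfur or the arrangement of the hetero atoms in the ring, a question that a thiazol-2-yl or a 1,3,4-thiadiazol-2-yl group on the same nitrogen would address. Also open, on these data alone, is how an ethyl chain or a phenyl ring bound directly to that nitrogen would compare with methyl.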